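This account rests on a few compounds, and the source may have more. Where it says the series, first, only, none or still open, it means among the compounds named here.

Compound 1 `COc1ccc(/C(Cl)=C/C=C(\C#N)C(=O)c2c[nH]c3ccc(Br)cc23)cc1` is measured in a functional assay for inhibition, with a stated time of 5 min, tested at 1 mM (on this read-out higher numbers stand for more inhibition at the one concentration tested (going by the name of the read-out) and lower numbers for less inhibition), and gives 62.2%. Its companion, compound 2 `COc1ccc(/C(Cl)=C/C=C(\C#N)C(=O)c2c[nH]c3ccc(OC)cc23)cc1`, differs from it at one place, methoxy in place of bromo on an aromatic carbon, and in this assay compound 2 gives 60.7%. The step of a number 1.5 percentage points lower from compound 1 to compound 2 (within the scatter) is within the scatter, so the two measured compounds cannot be told apart on this read-out. For the measured compounds named here, of the two numbers, compound 1 holds the higher one, with compound 2 as its only neighbour, a short distance away that the scatter covers.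

Compound 3 `COc1ccc(/C(Cl)=C/C=C(\C#N)C(=O)c2c[nH]c3ccc(Br)cc23)cc1OC` is not yet measured. It differs from compound 1 by methoxy in place of hydrogen on an aromatic carbon. Going by the values given here, only one measured step exists, the bromo-to-methoxy swap from compound 1 to compound 2, and it sits on a different part of the structure, so it bears on the present change only by showing that a small alteration left this assay unchanged within the scatter. Nothing in the two measured values points toward a move in either direction. Compound 3 is therefore expected to give about 60%, within 46% to 72%, a step of a number 2.2 percentage points lower from compound 1 to compound 3 (within the scatter) that is expected to stay within the scatter.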

Compound 3, a percentage reported as inhibition, at one concentration (the size of the read-out at that concentration, not a potency): 80.9%
The estimate for compound 3 lay 20.9 percentage points below the measured number; measured number outside the range, above it.
By their numbers in this assay, from the lowest: compounds 2 and 1 (each within the scatter of the next); then compound 3.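

In this assay the aromatic carbon ortho to a methoxy group and meta to a large group proves to be a place where the read-out responds: methoxy in place of hydrogen there gives a number 18.7 percentage points higher from compound 1 to compound 3 (beyond the scatter) and so moves the number clearly. For the compounds shown here, the only earlier step, at another place on the molecule, was a number 1.5 percentage points lower from compound 1 to compound 2 (within the scatter) and showed no such movement, so the two steps now differ in kind, one within the scatter and one beyond it. Nothing measured here accounts for the gain in inhibition at this carbon.

The compounds shown leave open whether the gain belongs to methoxy in particular, or whether a hydroxy group, an ethoxy group, a fluorine atom or a dimethylamino group on the same aromatic carbon would move the number in the same direction and by a similar amount. They also leave open whether the same added methoxy would give a step of like size on compound 2, where methoxy stands in place of bromo.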